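The compounds below may be only part of what the source reports. "The series", "measured", "known", "first", "only" and "open" are said of these compounds alone.

Measured so far in a functional assay on MCF7 cells (Homo sapiens) for antiproliferative activity, read by sulforhodamine B assay, with a stated time of 72 h, tested at 30 uM; a lower number here means a stronger effect, a higher number a weaker effect of the compound at the concentration tested:
compound 1 `COc1cc(Br)cc(/C=C/C(=O)c2ccccc2)c1O` 28.1%
compound 2 `COc1cc(Br)cc(/C=C/C(=O)c2ccc(Br)cc2)c1O` 48.3%
compound 3 `COC(=O)C1=C(N)Oc2c(OC)cc(Br)cc2C1CC(=O)c1ccc(Cl)cc1` 33.8%

Between compound 2 and compound 1 the change is hydrogen in place of bromo on an aromatic carbon, and the step of a number 20.2 percentage points lower from compound 2 to compound 1 (beyond the scatter). Compound 3 stands on another core; the difference between the two cores is not broken down here. Compound 4 `COC(=O)C1=C(N)Oc2c(OC)cccc2C1CC(=O)c1ccc(Cl)cc1` is not yet measured; it differs from compound 3 by hydrogen in place of bromo on an aromatic carbon. This is the same kind of change as the earlier one, not the same: the earlier place is para to a large group, whereas here the carbon is part of a fused or bridged system of two rings, meta to a fused ring, meta to a methoxy group and para to a fused ring. Within the data shown here, the only measured example points toward a lower number, but on a different place, so a smaller step is expected from compound 3 to compound 4, a number 2.2 percentage points higher from compound 3 to compound 4 (within the scatter), set beside the earlier one with caution. Compound 4 is estimated at 36%, within 20% to 58%.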

Compound 4, a percentage reported as activity, at one concentration (the size of the read-out at that concentration, not a potency): 63.8%
For compound 4 the middle estimate is 27.8 percentage points below the measured one, outside the stated range (above it).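

Hydrogen in place of bromo on an aromatic carbon does not behave the same way on the two cores in this assay: the same change on two cores in this assay, a number 20.2 percentage points lower (beyond the scatter) from compound 2 to compound 1 and a number 30 percentage points higher (beyond the scatter) from compound 3 to compound 4, 50.2 percentage points apart, beyond the scatter of two such steps

On the second core the change gives a number 30 percentage points higher from compound 3 to compound 4 (beyond the scatter), opposite in direction to the step on the first core, so the direction of this change cannot be carried from one core to the other in this series. What lies behind the reversal is not shown: core and place of the change differ together, and each core offers a single pair.

The compounds shown leave open how the second core responds to other groups at this place, such as an amine or a carboxylic acid. Going by these compounds, whether hydrogen in place of the chloro group follows either direction also stays open.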